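From an imidazolyl substituent to plain hydrogen

A few compounds are considered here, and "the series" means these few. Any claim that something is new, unique, unknown or untested is made for them only; others in the source may bear on it.

Three acylguanidines with a shared core have been measured in a functional assay for inhibition of sodium/hydrogen exchanger (Oryctolagus cuniculus); a higher number here means a weaker inhibitor, a lower number a stronger inhibitor. Compound 1 `Cc1cc(OC(C)(C)C)c(S(C)(=O)=O)cc1C(=O)N=C(N)N` gives 9.4 nM. Compound 2 `Cc1cc(Oc2cccc(Cl)c2)c(S(C)(=O)=O)cc1C(=O)N=C(N)N` gives 21 nM. Compound 3 `Cc1cc(-n2ccnc2C)c(S(C)(=O)=O)cc1C(=O)N=C(N)N` gives 29 nM, the highest of the three numbers; its gap to compound 2 lies within the scatter, while its gap to compound 1 lies beyond it.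

Compound 4 `Cc1ccc(S(C)(=O)=O)cc1C(=O)N=C(N)N` differs from compound 3 in one place: hydrogen in place of 2-methyl-1H-imidazol-1-yl on an aromatic carbon. Within the data shown here, none of the measured steps removes the group at this position altogether; each swaps one group for another. The swap a 2.2-fold higher number from compound 1 to compound 2 (0.35 log units; beyond the scatter) and the swap a 3.1-fold higher number from compound 1 to compound 3 (0.49 log units; beyond the scatter) each gave a modest rise, and the swap a 1.4-fold higher number from compound 2 to compound 3 (0.14 log units; within the scatter) stayed within the scatter. These show that what sits at this position moves the number only modestly, but they say nothing about leaving it empty. Taking the loss of a whole group as more than another swap, a rise beyond the scatter is expected, a 3.4-fold higher number from compound 3 to compound 4 (0.54 log units; beyond the scatter). Compound 4 is therefore estimated at 100 nM, with a range from 25 nM to 400 nM.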

Compound 4, half-maximal inhibitory concentration: 150 nM
The estimate for compound 4 lay 1.5-fold (0.18 log units) below the measured number; the range from low to high includes it.
By their numbers in this assay, from the lowest: compound 1; then compounds 2 and 3 (each within the scatter of the next); then compound 4.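

Leaving this position empty gives in this assay a bigger rise than any swap of one group for another did: a 5.2-fold higher number from compound 3 to compound 4 (0.71 log units; beyond the scatter) and a 7.1-fold higher number from compound 2 to compound 4 (0.85 log units; beyond the scatter) and then a 16-fold higher number from compound 1 to compound 4 (1.20 log units; beyond the scatter) as the only large step so far. All three groups, tert-butoxy, 3-chlorophenoxy and 2-methyl-1H-imidazol-1-yl, therefore give a lower number than hydrogen, though they have little in common beyond sitting at this position. Among these four compounds, having a group here matters more than which of the three it is.

No measurement is at hand to say why a group here lowers the number. Also open, on these data alone, is how small a group can be and still do this, for instance a lone methoxy, and whether an amine or a carboxylic acid here would behave like the three groups.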